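The compounds below may be only part of what the source reports. "The series", "measured", "known", "first", "only" and "open" are said of these compounds alone.

Measured in an ADME assay on HeLa cells (Homo sapiens) for cytotoxicity, read by MTT assay; a higher number here means a weaker inhibitor, a lower number a stronger inhibitor:
- Compound 1 `COc1ccc(C[C@H]2COC(=O)[C@@H]2Cc2ccc(OCc3cn(-c4ccc(F)cc4)nn3)c(OC)c2)cc1OC`: >= 600000 nM (a limit)
- Compound 2 `COc1ccc(C[C@H]2COC(=O)[C@@H]2Cc2ccc(OCc3cn(Cc4ccc(Cl)cc4)nn3)c(OC)c2)cc1OC`: 242000 nM

Among the measured compounds shown here, compound 2 holds the only true number so far. Compound 1 stands at the limit of >= 600000 nM. Compound 3 `COc1ccc(C[C@H]2COC(=O)[C@@H]2Cc2ccc(OCc3cn(-c4ccc(Br)cc4)nn3)c(OC)c2)cc1OC` differs from compound 2 by one change: 4-bromophenyl in place of 4-chlorobenzyl on an aromatic nitrogen. For the measured compounds named here, the one measured step that bears on this is an at least 2.4-fold lower number from compound 1 to compound 2 (0.39 log units; beyond the scatter), and compound 3 again carries a phenyl group on that nitrogen, so a step of similar size towards a higher number is expected in this assay. Compound 3 is estimated at 480000 nM, with an expected range of 220000 nM to 1000000 nM. This estimate means an expected 2.0-fold higher number from compound 2 to compound 3 (0.30 log units; within the scatter).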

Compound 3, half-maximal inhibitory concentration: 128000 nM
Beside the measured number, compound 3's estimate is 3.8-fold (0.57 log units) above it; measured number outside the range, below it.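

On the aromatic nitrogen, a phenyl group does not by itself keep the number high in this assay: bromo in place of fluoro on an aromatic carbon gives an at least 4.6-fold lower number from compound 1 to compound 3 (0.67 log units; beyond the scatter) within the same phenyl series. The change to 4-bromophenyl from 4-chlorobenzyl gives a 1.9-fold lower number from compound 2 to compound 3 (0.28 log units; within the scatter), so the two groups are not told apart here. Compound 1 is held only as a limit, so its step is open on one side: the limit of >= 600000 nM in this assay, at which 1 of the 3 values shown sits.

Still open, from the compounds shown here alone, is how a phenyl group carrying chloro or a benzyl group carrying bromo would read, and whether an amine or a carboxylic acid on that ring would shift the number in this assay at all.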